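Fluoro added to the aryl sulfonamide of compound 2

A few compounds are considered here, and "the series" means these few. Any claim that something is new, unique, unknown or untested is made for them only; others in the source may bear on it.

Measured compounds:
compound 1, `CCCCCCCCCCc1cn(C[C@H](O)[C@H]2OC(=O)C(OCc3ccccc3)=C2OCc2ccccc2)nn1`, 12200 nM
compound 2, `O=C1O[C@H]([C@@H](O)Cn2cc(CNS(=O)(=O)c3ccc(Cl)cc3)nn2)C(OCc2ccccc2)=C1OCc1ccccc1`, 7510 nM

In a functional assay on HepG2 cells (Homo sapiens) for antiproliferative activity, read by MTT assay, with a stated time of 72 h (on this read-out lower numbers stand for stronger inhibition and higher numbers for weaker inhibition), compound 1 gives 12200 nM. Its analogue compound 2, in which the nonyl chain is replaced by a ((4-chlorophenyl)sulfonyl)amino group on the saturated chain carbon bound to the aromatic carbon, gives 7510 nM in this assay. The difference, a 1.6-fold lower number from compound 1 to compound 2 (0.21 log units; within the scatter), lies within the scatter, so the two compounds are to be taken as equal on this read-out; compound 2 merely has the lower of the two numbers.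

Compound 3, `O=C1O[C@H]([C@@H](O)Cn2cc(CNS(=O)(=O)c3ccc(Cl)cc3F)nn2)C(OCc2ccccc2)=C1OCc1ccccc1`, is the next variation on compound 2. The change is fluoro in place of hydrogen on an aromatic carbon, so that the (4-chlorophenyl)sulfonyl group becomes a (4-chloro-2-fluorophenyl)sulfonyl group. For the measured compounds named here, no measured step touches this ring: the only step at hand, from compound 1 to compound 2, exchanges the whole side chain and is itself within the scatter. There is therefore no basis for expecting a step beyond the scatter from compound 2 to compound 3.

The expected value for compound 3 in this assay is accordingly 7000 nM, with a range of 2500 nM to 20000 nM, the expected step being a 1.1-fold lower number from compound 2 to compound 3 (0.03 log units; within the scatter).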

Compound 3, half-maximal inhibitory concentration: 25500 nM
The estimate for compound 3 lay 3.6-fold (0.56 log units) below the measured number; measured number above the stated range.
By their numbers in this assay, from the lowest: compounds 2 and 1 (each within the scatter of the next); then compound 3.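

In this assay, the aromatic carbon ortho to a large group proves sensitive to a single added atom: fluoro in place of hydrogen there gives a 3.4-fold higher number from compound 2 to compound 3 (0.53 log units; beyond the scatter) and so moves the number beyond the scatter, although it leaves the rest of compound 2 unchanged. For the compounds shown here, the earlier exchange of the whole side chain, a 1.6-fold lower number from compound 1 to compound 2 (0.21 log units; within the scatter), stayed within the scatter, so the earlier compounds gave no sign that this ring could shift the read-out. With the fluoro in place, the same side-chain exchange gives a 2.1-fold higher number from compound 1 to compound 3 (0.32 log units; beyond the scatter) and no longer leaves the sulfonamide level with the nonyl compound, while nothing in the available data explains the rise.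

The compounds shown leave open whether the rise belongs to fluoro itself or to any group on this carbon, a question that a methyl, methoxy or chloro group at the same place could help to settle. They also leave open whether fluoro would give a step of similar size on the phenyl ring without its chloro group.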